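Selenoether ester series: phenyl for 2-phenylethenyl at the carbonyl

The source may report more compounds than this note shows. Statements on the series, on what has been measured and on what is new or still open speak of the compounds shown alone.

Two compounds of this series carry measured numbers in a functional assay on SW707 cells (Homo sapiens) for antiproliferative activity, with a stated time of 72 h; on this read-out lower numbers stand for stronger inhibition and higher numbers for weaker inhibition. Compound 1, `CSc1cnc2ccccc2c1[Se]CC#CCOC(=O)/C=C/c1ccccc1`, gives 4.7 ug/mL, the lowest of the two numbers available. Compound 2, `C#CCSc1cnc2ccccc2c1SCC#CCCl`, gives 12.9 ug/mL in this assay, a higher number than compound 1, and the gap between them is stated to lie beyond the usual scatter. Compound 2 differs from compound 1 in more than one place, so no single step can be read from that pair; only the two values themselves stand.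

Compound 3, `CSc1cnc2ccccc2c1[Se]CC#CCOC(=O)c1ccccc1`, shares the core of compound 1 and differs in the ester: phenyl in place of 2-phenylethenyl on a carbonyl carbon. The carbonyl carbon keeps its oxygen next to a carbonyl group as its other neighbour. Nothing measured in this assay separates a phenyl ester from a 2-phenylethenyl ester here, so no step size can be quoted from the data; the alteration is confined to the terminal acyl group while the rest of compound 1 is kept.

For compound 3 a step of a 1.3-fold higher number from compound 1 to compound 3 (0.11 log units; within the scatter) is expected in this assay, small and likely within the scatter, leaning toward a slightly higher number. Compound 3 is estimated at 6 ug/mL, in the range 2.5 ug/mL to 14 ug/mL.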

Compound 3, concentration for 50% inhibition: 3.6 ug/mL
Estimate against measurement, compound 3: 1.7-fold (0.22 log units) above; low and high end bracket the measured number.
By their numbers in this assay, from the lowest: compounds 3 and 1 (each within the scatter of the next); then compound 2.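

In this assay, replacing 2-phenylethenyl with phenyl on a carbonyl carbon whose other neighbours are oxygen next to a carbonyl group gives a 1.3-fold lower number from compound 1 to compound 3 (0.12 log units; within the scatter), so the two esters cannot be told apart on this read-out. Among the compounds shown here, the first measured step at this position therefore shows that the acyl group can lose its double bond outside aromatic rings and go from 8 to 6 heavy atoms, keeping its six-membered aromatic ring, without a change beyond the scatter. No measurement in hand accounts for this result.

Both acyl groups shown carry a six-membered aromatic ring of carbon only, so it remains open whether a methyl group, a longer saturated chain or an amine in that place would leave the number within the scatter. Steps to compound 2 cannot be read, as it differs from the other compounds in more than one place, so the effect of selenium against sulfur in the shared core also remains open.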